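The source may report more compounds than this note shows. Statements on the series, on what has been measured and on what is new or still open speak of the compounds shown alone.

Of the compounds shown here, three have so far been tested in a functional assay on the whole organism (blood, strain Wistar-Okamoto) with Rattus norvegicus as the target, with a stated time of 5 days; a lower number here means that less compound is needed, a higher number that more compound is needed for the effect. Compound 1, `CCC/N=C(\NC#N)Nc1cccnc1`, gives 20 mg/kg. Compound 2, `CCCC/N=C(\NC#N)Nc1cccnc1`, gives 20 mg/kg. The two differ in one place, (methyl in place of hydrogen on a saturated chain carbon, three bonds along the chain from a double-bonded nitrogen), and the step of no change at the digits printed from compound 1 to compound 2 (within the scatter). Compound 3, `N#CN/C(=N\Cc1ccccc1)Nc1ccncc1`, gives 5 mg/kg, the lowest of the three numbers; how its core differs from the core of compound 1 is not broken down here. Compound 4, `CC(/N=C(\NC#N)Nc1ccncc1)c1ccccc1`, has not yet been measured in this assay. It differs from compound 3 by methyl in place of hydrogen on a saturated chain carbon bound to an aromatic carbon and a double-bonded nitrogen, the same kind of change as that from compound 1 to compound 2, though not the same: in compound 4 the methyl enters on a saturated chain carbon bound to an aromatic carbon and a double-bonded nitrogen, whereas in compound 2 it enters on a saturated chain carbon, three bonds along the chain from a double-bonded nitrogen. Because no change at the digits printed from compound 1 to compound 2 (within the scatter), compound 4 is expected to show a step of about no change at the digits printed from compound 3 to compound 4 (within the scatter). Compound 4 is therefore estimated at 5 mg/kg, with a range from 2.5 mg/kg to 12 mg/kg.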

Compound 4, minimum effective dose: 10 mg/kg
Compound 4: the middle estimate sits 2.0-fold (0.30 log units) below what was measured, within the range that was stated.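

In this assay, methyl in place of hydrogen on a saturated chain carbon bound to an aromatic carbon and a double-bonded nitrogen gives a 2.0-fold higher number from compound 3 to compound 4 (0.30 log units; within the scatter). Set beside the earlier step, the change carries from one core to the other without a difference that stands out from the scatter: the same change on two cores in this assay, no change at the digits printed (within the scatter) from compound 1 to compound 2 and a 2.0-fold higher number (0.30 log units; within the scatter) from compound 3 to compound 4, 2.0-fold (0.30 log units) apart, within the scatter of two such steps. This does not show that the methyl acts alike on both cores, for each step rests on a single pair, the methyl enters at a different place in each pair, and neither step lies beyond the scatter.

The compounds shown leave open whether methyl at the place it occupies in compound 4 would give a similar step on the core of compound 1. They also leave open whether a longer chain or an amine on that same saturated carbon would move the number beyond the scatter.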